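The source may hold more compounds than are shown below. What is called first, only, known or untested is meant among the compounds shown, and "the series" means these compounds.

Measured compounds:
compound 1 `O=C(Nc1ccc2cccnc2c1)c1ccc(-c2ccccc2F)nc1` — 8.7
compound 2 `Cc1nc(-c2ccc(F)cc2)ccc1C(=O)Nc1ccc2ccn(C)c2c1` — < 6.5 (a limit of the assay, not a number)
compound 3 `Cc1nc(-c2ccc(F)cc2)ccc1C(=O)Nc1ccc2c(C)n[nH]c2c1` — 6.9

In an in vitro functional assay on 1321-N1 cells for antagonist activity at transient receptor potential cation channel subfamily V member 1 (Homo sapiens), read by FLIPR and calcium flux (on this read-out lower numbers stand for lower potency and higher numbers for higher potency (the scale is a negative logarithm)), compound 1 gives 8.7, the highest of the two numbers measured. The nearest number belongs to compound 3, which gives 6.9 in this assay, a gap that lies beyond the usual scatter of repeated measurements. Compound 2 reaches only a limit of the assay, (the limit of < 6.5 in this assay, at which 1 of the 3 values shown sits), and no number is known for it. Within the data shown here, no two of the measured compounds differ in a single place, so no measured step is available to calibrate the change that follows.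

Compound 4 `N#Cc1ccc(C(=O)Nc2ccc3cccnc3c2)cn1` is not yet measured in this assay. It differs from compound 1 by cyano in place of 2-fluorophenyl on an aromatic carbon. Among the measured compounds shown here, the change trades a whole six-membered aromatic ring of carbon for a two-atom cyano, and with no measured step of this kind on hand the expectation rests on the structural change alone. The step from compound 1 to compound 4 is expected to be a decrease in this assay well beyond the scatter, a number 1.70 log units lower from compound 1 to compound 4 (beyond the scatter). Compound 4 is therefore estimated at 7, within a range from 6 to 8.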

Compound 4, negative logarithm of the antagonist equilibrium constant: < 6.7
Compound 4 ended at the assay's limit; the forecaster's own chance of this, stated with the estimate: 25%; middle value at least 0.30 log units from the limit.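

In this assay, the exchange of 2-fluorophenyl for cyano on this aromatic carbon, next to the ring nitrogen, gives a number at least 2.00 log units lower from compound 1 to compound 4 (beyond the scatter). Compound 4 stands at a limit of the assay, not at a number: the limit of < 6.7 in this assay, at which 1 of the 4 values shown sits.

Among these compounds, this is the first step in the set that changes one place only, and it shows that the potency of compound 1 does not survive this exchange, which compound 2 and compound 3, each differing from compound 1 in more than one place, could not show. From the compounds shown here alone, the full size of the step stays unknown, and this single step does not separate the loss of the ring from the loss of the fluorine or the arrival of the nitrile. Going by these compounds, whether an unsubstituted phenyl, a morpholine or a short alkoxy chain here would hold the potency of compound 1 remains open.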